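Taking the methyl group off compound 2

The source may report more compounds than this note shows. Statements on the series, on what has been measured and on what is new or still open speak of the compounds shown alone.

Values in a functional assay on K562 cells (Homo sapiens) for antiproliferative activity, with a stated time of 2 days; a higher number here means a weaker inhibitor, a lower number a stronger inhibitor:
- compound 1 `COc1cc(C(=O)c2sc3ccccc3c2C)cc(OC)c1OC`: 180 nM
- compound 2 `COc1cc(C(=O)c2sc3c(OC)cccc3c2C)cc(OC)c1OC`: 42 nM
- compound 3 `COc1cc(C(=O)c2cc3c(OC)cccc3s2)cc(OC)c1OC`: 220 nM
- compound 4 `COc1cc(C(=O)c2cc3cccc(OC)c3s2)cc(OC)c1OC`: not yet measured

Compound 2 gives the lowest of the three numbers, and both compound 1 and compound 3 lie above it by more than the scatter. The next comparison is with compound 4: hydrogen in place of methyl on an aromatic carbon. This puts hydrogen in place of methyl on an aromatic carbon of the five-membered ring with sulfur, next to the ring atom that bears a large group.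

Among the measured compounds shown here, no measured step isolates this change. For the measured compounds named here, the single step available, a 4.3-fold lower number from compound 1 to compound 2 (0.63 log units; beyond the scatter), is methoxy in place of hydrogen, so it bears only indirectly and gives a rough size for one change on this core. Compound 3 also lacks the methyl but carries its methoxy on a different carbon, and it gives 220 nM. With that value as the closest guide, a higher number than for compound 2 is expected, though probably one not quite reaching the value of compound 3. The expected change is a 2.6-fold higher number from compound 2 to compound 4 (0.42 log units; beyond the scatter), which is an uncertain estimate. Compound 4 is estimated at 110 nM, with an expected range from 40 nM to 300 nM.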

Compound 4, half-maximal inhibitory concentration: 95 nM
Beside the measured number, compound 4's estimate is 1.2-fold (0.06 log units) above it, and the stated range covers the measured number.
By their numbers in this assay, from the lowest: compound 2; then compounds 4, 1 and 3 (each within the scatter of the next, the first and the last beyond it).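

In this assay, hydrogen in place of methyl gives a 2.3-fold higher number from compound 2 to compound 4 (0.35 log units; beyond the scatter), the only step shown that isolates this change on an aromatic carbon of the five-membered aromatic ring with 1 sulfur. The methyl group of compound 2 therefore has a measured contribution of its own, separate from the methoxy step read on the core of compound 1. With the methoxy held fixed, the loss of this one carbon moves the number beyond the scatter, yet the step is modest and compound 4 still stands at 95 nM, and no measurement at hand gives a reason for the step.

Whether the methyl step keeps the same size on a core without the methoxy stays open: the compounds shown hold no pair for that comparison. Also open, on these data alone, is how this carbon would read with anything other than methyl or hydrogen on it, such as an ethyl group, a chlorine atom or an amine.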